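A New Amide Substituent on a Phenyl Compound

This account rests on a few compounds, and the source may have more. Where it says the series, first, only, none or still open, it means among the compounds named here.

In a functional assay on MDA-MB-231 cells (Homo sapiens) for cytotoxicity, read by MTT assay, with a stated time of 72 h (on this read-out lower numbers stand for stronger inhibition and higher numbers for weaker inhibition), compound 1 (`COc1ccc(NC(=O)CN2CCN(c3nnc(Cc4ccncc4)c4ccccc34)CC2)cc1OC`) gives 100 nM and compound 2 (`O=C(CN1CCN(c2nnc(Cc3ccncc3)c3ccccc23)CC1)Nc1ccc(F)c(C(F)(F)F)c1`) gives 1.9 nM. That change, a 53-fold lower number from compound 1 to compound 2 (1.72 log units; beyond the scatter), came with 4-fluoro-3-(trifluoromethyl)phenyl in place of 3,4-dimethoxyphenyl on an amide-type nitrogen. Compound 3 (`COc1ccc(NC(=O)CN2CCN(c3nnc(Cc4ccccc4)c4ccccc34)CC2)cc1OC`) reads 32200 nM, the highest of the three numbers. The step of a 320-fold higher number from compound 1 to compound 3 (2.51 log units; beyond the scatter) came with phenyl in place of pyridin-4-yl.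

Compound 4 (`Cc1cccc(Cl)c1NC(=O)CN1CCN(c2nnc(Cc3ccccc3)c3ccccc23)CC1`) keeps the phenyl of compound 3 and differs only at the amide: 2-chloro-6-methylphenyl in place of 3,4-dimethoxyphenyl on an amide-type nitrogen. In words, 2-chloro-6-methylphenyl stands in place of 3,4-dimethoxyphenyl on an amide-type nitrogen. Among the compounds with values here, only the step of a 53-fold lower number from compound 1 to compound 2 (1.72 log units; beyond the scatter) replaces this same group, but it was measured with pyridin-4-yl present and with a different entering group. Within the data shown here, no measured pair shows how such a replacement behaves alongside phenyl, so its size cannot simply be carried over. The step of a 320-fold higher number from compound 1 to compound 3 (2.51 log units; beyond the scatter) shows only that the two series can lie far apart. A lower number is therefore expected in this assay, probably by a large step, though a smaller one than that seen for compound 2.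

The expected change is a 13-fold lower number from compound 3 to compound 4 (1.11 log units; beyond the scatter). For compound 4 the estimated value is 2500 nM, with an expected range from 100 nM to 30000 nM.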

Compound 4, half-maximal inhibitory concentration: 3920 nM
Estimate against measurement, compound 4: 1.6-fold (0.20 log units) below, and the stated range covers the measured number.
By their numbers in this assay, from the lowest: compound 2; then compound 1; then compound 4; then compound 3.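

Within the data shown here, with phenyl kept in the core, 2-chloro-6-methylphenyl in place of 3,4-dimethoxyphenyl on the amide-type nitrogen gives an 8.2-fold lower number from compound 3 to compound 4 (0.91 log units; beyond the scatter) in this assay, so this position also moves the number in the phenyl series, whereas the earlier compounds showed a change there only with pyridin-4-yl present. The step is modest beside a 53-fold lower number from compound 1 to compound 2 (1.72 log units; beyond the scatter), but the two steps differ in both the entering group and the group on the chain carbon, so these data cannot say whether the gap in size comes from one, the other or both. No measurement here gives a reason for the change at the amide or for its size.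

The compounds shown leave open how 2-chloro-6-methylphenyl would read with pyridin-4-yl and how 4-fluoro-3-(trifluoromethyl)phenyl would read with phenyl, the two pairings that would separate the effect of the amide substituent from that of the other site. They also leave open how the amide-type nitrogen would tolerate a group of another kind, such as a cyclohexyl or a pyridin-3-yl group, in place of the substituted phenyl rings.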